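The source may hold more compounds than are shown below. What is called first, only, known or untested is meant among the compounds shown, and "the series" means these compounds.

Going by the values given here, compound 2 `COc1cc(-c2cnn3cc(OC)c(C(C)C)nc23)ccn1` gives 3800 nM in an assay on isolated protein for inhibition of activin receptor type-2A (Homo sapiens), read by 33P incorporation, with a stated time of 20 min, in the presence of a further agent that is not named here (a lower number here means a stronger inhibitor, a higher number a weaker inhibitor), and stands highest of the two numbers so far. Its nearest neighbour is compound 1 `COc1cc(-c2cnn3cc(OC)c(-c4cc(C)no4)nc23)ccn1` at 3000 nM. The step of a 1.3-fold higher number from compound 1 to compound 2 (0.10 log units; within the scatter) lies within the scatter. Compound 3 `COc1cc(-c2cnn3cc(OC)c(C4CCCC4)nc23)ccn1` is not yet measured; it differs from compound 2 by cyclopentyl in place of isopropyl on an aromatic carbon. Among the compounds with values here, the only step at hand, a 1.3-fold higher number from compound 1 to compound 2 (0.10 log units; within the scatter), also exchanged the group on the same aromatic carbon and stayed within the scatter, so in this assay no shift beyond the scatter is expected, that is no change at the digits printed from compound 2 to compound 3 (within the scatter). Compound 3 is therefore estimated at 3800 nM, range 1500 nM to 9500 nM.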

Compound 3, half-maximal inhibitory concentration: 2900 nM
Beside the measured number, compound 3's estimate is 1.3-fold (0.12 log units) above it, within the range that was stated.
By their numbers in this assay, from the lowest: compounds 3, 1 and 2 (each within the scatter of the next).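

In this assay, a non-aromatic carbon ring on this aromatic carbon changes little: the step (a 1.3-fold lower number from compound 2 to compound 3 (0.12 log units; within the scatter)) lies within the scatter. Exchange of the aromatic 3-methyl-1,2-oxazol-5-yl for cyclopentyl also stays within the scatter (a 1.0-fold lower number from compound 1 to compound 3 (0.01 log units; within the scatter)), so the three groups cannot be told apart at this position. Nothing on hand bears on the reason. On these data alone, whether an amine, a carboxylic acid or a longer chain on this carbon would give a step beyond the scatter remains open. As far as these compounds go, the effect of changes elsewhere on the shared core also remains open.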